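From Fluoro to Methyl on Compound 2

This account rests on a few compounds, and the source may have more. Where it says the series, first, only, none or still open, it means among the compounds named here.

In an ADME assay on GES1 cells (Homo sapiens) for inhibition, read by MTT assay, with a stated time of 72 h (a higher number here means a weaker inhibitor, a lower number a stronger inhibitor), compound 1 `Cc1cc(Nc2cc(-c3ccccc3)[nH]n2)n2nc(SCC3CCCCC3)nc2n1` gives > 50000 nM as a limit and not a number. Going by the values given here, compound 2 `Cc1cc(Nc2ccn(Cc3ccc(F)cc3)n2)n2nc(SCc3ccc(Br)cc3)nc2n1` gives 40500 nM in this assay and is the only compound with an actual number so far. Compound 3 `Cc1ccc(Cn2ccc(Nc3cc(C)nc4nc(SCc5ccc(Br)cc5)nn34)n2)cc1` has methyl in place of fluoro on an aromatic carbon and so turns 4-fluorobenzyl into 4-methylbenzyl. Only compound 2 at 40500 nM anchors this swap, so the expected change a 1.0-fold higher number from compound 2 to compound 3 (0.02 log units; within the scatter) in this assay stays within the scatter. Compound 3 is estimated at 42000 nM with an expected range of 20000 nM to 70000 nM in this assay once tested.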

Compound 3, half-maximal inhibitory concentration: > 50000 nM
Compound 3: no number, only a limit (the forecaster's own chance of this, stated with the estimate: 35%); at least 1.1-fold (0.07 log units) between middle value and limit.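

Going by these compounds alone, this is the only comparison here between two compounds that differ in one place, and methyl in place of fluoro on the benzyl group gives an at least 1.2-fold higher number from compound 2 to compound 3 (0.09 log units; that floor lies within the scatter). It shows that the methyl compound, compound 3, also reaches the limit of the assay, so the step has a floor but no measured size. Its true size stays unknown because the read-out ends there: the limit of > 50000 nM in this assay, at which 2 of the 3 values shown sit.

From the compounds shown here alone, whether an amine or a carboxylic acid at this position would give a real number in this assay stays open. So does whether the fluoro in compound 2 matters at all.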